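The source may report more compounds than this note shows. Statements on the series, on what has been measured and on what is new or still open speak of the compounds shown alone.

Measured in a functional assay on L02 cells (Homo sapiens) for inhibition, read by MTT assay, with a stated time of 48 h; on this read-out lower numbers stand for stronger inhibition and higher numbers for weaker inhibition:
- Compound 1 `O=C(/C=C/c1coc2cc(O)ccc2c1=O)NCc1ccccc1`: > 200000 nM, a limit.
- Compound 2 `COc1ccc(NC(=O)/C=C/c2coc3cc(O)ccc3c2=O)cc1`: > 200000 nM, a limit.
- Compound 3 `COc1ccc2c(=O)c(/C=C/C(=O)NCc3ccc(C)cc3)coc2c1`: > 200000 nM, a limit.

Among the compounds with values here, compound 3 therefore has no numeric value, and the series so far rests on (the limit of > 200000 nM in this assay, at which 3 of the 3 values shown sit). Compound 4 `Cc1ccc(CNC(=O)/C=C/c2coc3cc(O)ccc3c2=O)cc1` has hydrogen in place of methyl on an oxygen on an aromatic ring, methoxy to hydroxy: hydrogen in place of methyl on an oxygen on an aromatic ring.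

Within the data shown here, the only measured step, a step that the two limits leave unreadable from compound 1 to compound 2, lies on an amide-type nitrogen rather than on this oxygen, and its size cannot be read. Compound 1 also carries the hydroxy and gives > 200000 nM, again a limit. No change beyond the scatter and no direction is therefore expected in this assay, with the expected step being a step that the limit leaves unreadable from compound 3 to compound 4. For compound 4 the estimate is 250000 nM, with an expected range of 100000 nM to 600000 nM, most likely reported only as a limit.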

Compound 4, half-maximal inhibitory concentration: > 200000 nM
Compound 4 was reported as a limit (the forecaster's own chance of this, stated with the estimate: 90%); the middle value lies beyond the limit too.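

Within the data shown here, no step among compound 1, compound 2, compound 3 and compound 4 can be read in this assay, since all four sit at one limit: the limit of > 200000 nM in this assay, at which 4 of the 4 values shown sit. The compounds shown leave open whether any change to the shared core gives a numeric value.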